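Hydroxy Partner of a Weak Sulfonyl Enone

The compounds below may be only part of what the source reports. "The series", "measured", "known", "first", "only" and "open" are said of these compounds alone.

Compound 2 `O=C(/C(=C\c1ccc(O)c([N+](=O)[O-])c1)S(=O)(=O)c1ccc(I)cc1)c1ccc(Br)cc1` gives 25000 nM in a functional assay on DU-145 cells (Homo sapiens) for inhibition, read by trypan blue exclusion, with a stated time of 96 h (on this read-out higher numbers stand for weaker inhibition of growth and lower numbers for stronger inhibition of growth), the highest of the two numbers recorded, while compound 1 `O=C(/C(=C\c1ccc(Cl)c([N+](=O)[O-])c1)Sc1ccc(Br)cc1)c1ccc(Br)cc1` gives 10000 nM in this assay, a gap beyond the scatter. Compound 3 `O=C(/C(=C\c1ccc(O)c([N+](=O)[O-])c1)Sc1ccc(Br)cc1)c1ccc(Br)cc1` has not yet been measured. It differs from compound 2 in one place: (4-bromophenyl)sulfanyl in place of (4-iodophenyl)sulfonyl on a double-bonded chain carbon bound to a carbonyl carbon and a double-bonded chain carbon. Going by the values given here, no measured pair tracks this change on its own. Compound 1 carries the same entering group and gives 10000 nM. On that basis the step of a 2.1-fold lower number from compound 2 to compound 3 (0.32 log units; beyond the scatter) is expected to bring a modestly lower number, roughly at the edge of the scatter. Compound 3 is thus expected to give about 12000 nM, within a range of 4000 nM to 35000 nM.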

Compound 3, concentration for 50% growth inhibition: 1000 nM
Beside the measured number, compound 3's estimate is 12-fold (1.08 log units) above it; the measured number lies below the stated range.
By their numbers in this assay, from the lowest: compound 3; then compound 1; then compound 2.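

In this assay, (4-bromophenyl)sulfanyl in place of (4-iodophenyl)sulfonyl on this double-bonded chain carbon brings a 25-fold lower number from compound 2 to compound 3 (1.40 log units; beyond the scatter), so this position responds strongly when the hydroxy group is kept. Hydroxy in place of chloro on an aromatic carbon brings a 10-fold lower number from compound 1 to compound 3 (1.00 log units; beyond the scatter), so that aromatic carbon matters as well. Nothing available explains either step.

The step at the chain carbon changes sulfonyl to sulfanyl and iodo to bromo together, and the compounds shown do not separate the two. From the compounds shown here alone, whether an amine or a methoxy group on that aromatic carbon would match hydroxy also remains open.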